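Cytotoxicity at the Assay Limit in Four Related Compounds

This account rests on a few compounds, and the source may have more. Where it says the series, first, only, none or still open, it means among the compounds named here.

compound 1 `CS(=O)(=O)c1nc(N)c2ccn(COCCO)c2n1`: > 100000 nM
compound 2 `CC(=O)OCCOCn1ccc2c(Cl)nc(Cl)nc21`: > 100000 nM
compound 3 `OCCOCn1ccc2c(Cl)nc(Cl)nc21`: > 100000 nM

In a functional assay on BSC-1 cells (Cercopithecidae) for cytotoxicity (on this read-out lower numbers stand for stronger inhibition and higher numbers for weaker inhibition), compound 1 gives > 100000 nM. For compound 1 this value is a limit of the assay and not a number. In this assay compound 2 gives > 100000 nM, which is also a limit. In this assay compound 3 gives > 100000 nM, again a limit. Compound 1 therefore stands where every measured compound stands, namely at the limit of > 100000 nM in this assay, at which 3 of the 3 values shown sit. Within the data shown here, the single step between measured compounds, a step that the two limits leave unreadable from compound 2 to compound 3, cannot be read, since both ends of it sit at the limit.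

Compound 4 `Nc1nc(N)c2ccn(COCCO)c2n1` differs from compound 1 in one place: amino in place of methylsulfonyl on an aromatic carbon. Among the measured compounds shown here, no measured step bears on this exchange; the only step on record concerns an ester and is unreadable. With all three values at the limit, there is no sign that any of these compounds inhibits the cells within the measured range, and nothing points to a change beyond the scatter for compound 4 either. Compound 4 is therefore expected to give about 150000 nM in this assay, within a range of 30000 nM to 1000000 nM. The estimated step that the limit leaves unreadable from compound 1 to compound 4 is essentially none, with the result most likely reported again as a limit.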

Compound 4, half-maximal inhibitory concentration: > 100000 nM
Compound 4 ended at the assay's limit; the forecaster's own chance of this, stated with the estimate: 80%; the middle value lies beyond the limit too.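

Compound 1 and compound 4 both end at a limit in this assay and not at a number, so no new step can be read from amino in place of methylsulfonyl. The compounds shown leave open whether any of them inhibits these cells at all, and whether that exchange alters the read-out: the limit of > 100000 nM in this assay, at which 4 of the 4 values shown sit.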